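The source may report more compounds than this note shows. Statements on the series, on what has been measured and on what is new or still open speak of the compounds shown alone.

Among the compounds with values here, in a functional assay on HepG2 cells (Homo sapiens) for cytotoxicity, read by MTT assay, with a stated time of 48 h (on this read-out lower numbers stand for stronger inhibition and higher numbers for weaker inhibition), compound 1 `O=C1/C(=C\c2ccc(O)c(O)c2)S/C(=N/c2ccccc2)N1Cc1ccncc1` gives 16200 nM and compound 2 `COc1cc(/C=C2/S/C(=N/c3ccccc3)N(Cc3ccncc3)C2=O)ccc1O` gives 28600 nM, so compound 2 stands within the scatter of the only other measured value. Compound 3 `CCOc1cc(/C=C2/S/C(=N/c3ccccc3)N(Cc3ccncc3)C2=O)ccc1O` differs from compound 2 by methyl in place of hydrogen on a saturated chain carbon bound to an oxygen on an aromatic ring, methoxy to ethoxy. Within the data shown here, the one measured step that bears on this is a 1.8-fold higher number from compound 1 to compound 2 (0.25 log units; within the scatter), a similar small addition at the same oxygen. No change beyond the scatter is therefore expected in this assay. The expected step is a 1.0-fold higher number from compound 2 to compound 3 (0.02 log units; within the scatter). For compound 3 the estimated value is 30000 nM, with an expected range of 14000 nM to 62000 nM.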

Compound 3, half-maximal inhibitory concentration: 20400 nM
For compound 3 the middle estimate is 1.5-fold (0.17 log units) above the measured one; measured number inside the range.
By their numbers in this assay, from the lowest: compounds 1, 3 and 2 (each within the scatter of the next).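

In this assay the change from methoxy to ethoxy gives a 1.4-fold lower number from compound 2 to compound 3 (0.15 log units; within the scatter) and the change from hydroxy to ethoxy gives a 1.3-fold higher number from compound 1 to compound 3 (0.10 log units; within the scatter). Hydrogen, methyl and ethyl on this oxygen therefore read alike, and extending methyl to ethyl adds no step beyond the scatter. No available evidence accounts for this flat result.

As far as these compounds go, whether a longer chain, or a chain ending in an amine or a carboxylic acid, on this oxygen would leave the scatter remains open. Also open, from the compounds shown here alone, is whether the same change reads alike on a core carrying other groups.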